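Swapping a Dichlorothiophene for a Dichlorophenyl on the Core

This account rests on a few compounds, and the source may have more. Where it says the series, first, only, none or still open, it means among the compounds named here.

Three compounds share one core. Compound 1 `CS(=O)(=O)c1ccc(Cc2nnc3n2N=C(c2cc(Cl)sc2S(N)(=O)=O)CS3)cc1` and compound 2 `CS(=O)(=O)c1ccc(Cc2nnc3n2N=C(c2cc(Cl)sc2Cl)CS3)cc1` were both tested in a functional assay on HT-29 cells (Homo sapiens) for cytotoxicity, read by MTT assay, with a stated time of 48 h, tested at 12.5 uM; a higher number here means a stronger effect of the compound at the concentration tested, a lower number a weaker effect. In this assay compound 1 gives 22.8%, a modest effect. Going by the values given here, compound 2 is reported in this assay only as "not active" (no number reported), without a number, so its standing is known merely as weak, and no step between compound 2 and compound 1 can be sized beyond noting that compound 1 shows a small measured effect while compound 2 does not. Compound 3 `CS(=O)(=O)c1ccc(Cc2nnc3n2N=C(c2ccc(Cl)cc2Cl)CS3)cc1` is the unmeasured one. The change from compound 2 to compound 3 is 2,4-dichlorophenyl in place of 2,5-dichlorothiophen-3-yl on a carbon with a double bond to nitrogen. Nothing measured here shows how such a swap shifts this assay, so no firm direction can be drawn from the data. Because compound 2 gives "not active" (no number reported) in this assay, compound 3 is expected to stay weak as well, at an estimated 12%, with a range from 0% to 30%.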

Compound 3, a percentage reported as activity, at one concentration (the size of the read-out at that concentration, not a potency): 28%
For compound 3 the middle estimate is 16 percentage points below the measured one, and the stated range covers the measured number.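

In this assay compound 3, with 2,4-dichlorophenyl on the carbon with a double bond to nitrogen, gives 28%, so a dichlorinated ring at this place can carry a measured effect, although the step from compound 2, which has no number, cannot be read. Putting 2,4-dichlorophenyl in place of 5-chloro-2-sulfamoylthiophen-3-yl gives a number 5.2 percentage points higher from compound 1 to compound 3 (within the scatter), which shows that among these compounds a measured effect at this place does not depend on the sulfamoyl group. Nothing given here explains these results.

As far as these compounds go, it remains open how an unchlorinated phenyl ring, or a phenyl ring bearing an amine or a carboxylic acid, would behave at this place. A single concentration also shows only how strong the effect of these compounds is at that concentration.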